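The source may hold more compounds than are shown below. What is called first, only, known or untested is meant among the compounds shown, and "the series" means these compounds.

Compound 3 `CCn1c(C(=O)NCC(OC)OC)ccc1C(CC)(CC)c1ccc(OCC(O)C(C)(C)C)c(C)c1` gives in a functional assay on MCF7 cells (Homo sapiens), read by MTT assay, with a stated time of 48 h (on this read-out lower numbers stand for stronger inhibition and higher numbers for weaker inhibition), only a limit of the assay and not a number, > 50000 nM (the limit of > 50000 nM in this assay, at which 1 of the 3 values shown sits). Among the measured compounds shown here, the two numbers in the set belong to compound 1 `CCN(CC)CCNC(=O)c1ccc(C(CC)(CC)c2ccc(OCC(=O)C(C)(C)C)c(C)c2)n1CC`, which gives 690 nM in this assay, and to compound 2 `CCn1c(C(=O)NCCN)ccc1C(CC)(CC)c1ccc(OCC(=O)C(C)(C)C)c(C)c1`, which gives 75 nM in this assay; between them stands a 9.2-fold lower number from compound 1 to compound 2 (0.96 log units; beyond the scatter), the only measured step. Compound 4 `CCn1c(C(=O)OCc2ccc(F)cc2)ccc1C(CC)(CC)c1ccc(OCC(O)C(C)(C)C)c(C)c1` is reached from compound 3 by (4-fluorobenzyl)oxy in place of (2,2-dimethoxyethyl)amino on a carbonyl carbon. For the measured compounds named here, no measured step touches the carbonyl carbon, so the step from compound 1 to compound 2 does not bear on this change, and compound 3 supplies no number to scale from. Compound 4 is expected to stay far from the measured pair, at 20000 nM (range 3000 nM to 50000 nM), which would mean an expected at least 2.5-fold lower number from compound 3 to compound 4 (0.39 log units; beyond the scatter).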

Compound 4, half-maximal inhibitory concentration: > 50000 nM
Compound 4: no number, only a limit; the forecaster's own chance of this, stated with the estimate: 50%; middle value at least 2.5-fold (0.39 log units) from the limit.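

Among the compounds shown here, compound 3 and compound 4 both end at a limit of the assay, not a number, so no step between them can be read: the limit of > 50000 nM in this assay, at which 2 of the 4 values shown sit. Left open is whether (4-fluorobenzyl)oxy and (2,2-dimethoxyethyl)amino on the carbonyl carbon differ at all in their effect on this read-out.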